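The source may hold more compounds than are shown below. What is called first, only, known or untested is meant among the compounds shown, and "the series" means these compounds.

Measured compounds in an assay on isolated protein for displacement of a labelled ligand from Gonadotropin-releasing hormone receptor (Rattus norvegicus); on this read-out higher numbers stand for weaker inhibition and lower numbers for stronger inhibition:
- compound 1 `Cc1nc(C)c(CN2CCN(c3cccc4[nH]c(-c5ccc(C(C)(C)C)cc5)nc34)CC2)o1` gives 740 nM
- compound 2 `CCc1nc(C)c(CN2CCN(c3cccc4[nH]c(-c5ccc(C(C)(C)C)cc5)nc34)CC2)s1` gives 120 nM
- compound 3 `CCc1nc(CN2CCN(c3cccc4[nH]c(-c5ccc(C(C)(C)C)cc5)nc34)CC2)cn1C` gives 78 nM

Compound 2 holds the second highest of the three numbers; its nearest neighbour is compound 3, from which it is separated by a step within the scatter, and its furthest is compound 1, separated by a step beyond the scatter. The compound to be measured is compound 4 `CCCn1c(CC)nc(C)c1CN1CCN(c2cccc3[nH]c(-c4ccc(C(C)(C)C)cc4)nc23)CC1`. Relative to compound 2 the change is 2-ethyl-4-methyl-1-propyl-1H-imidazol-5-yl in place of 2-ethyl-4-methyl-1,3-thiazol-5-yl on a saturated chain carbon bound to an amine nitrogen in a ring.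

The step that bears most directly on this is a 1.5-fold lower number from compound 2 to compound 3 (0.19 log units; within the scatter), which also replaces the 2-ethyl-4-methyl-1,3-thiazol-5-yl ring with an imidazole-type ring, though with a different substitution pattern. The larger steps of a 6.2-fold lower number from compound 1 to compound 2 (0.79 log units; beyond the scatter) and a 9.5-fold lower number from compound 1 to compound 3 (0.98 log units; beyond the scatter) show that the 2,4-dimethyl-1,3-oxazol-5-yl ring is the weakest of the three head groups, while the thiazole and imidazole variants sit close together. Among the compounds with values here, no measured step isolates the effect of the 1-propyl group or of moving the attachment to the 5-position of the imidazole.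

The expected step is therefore a 1.3-fold lower number from compound 2 to compound 4 (0.12 log units; within the scatter), a small shift toward a lower number that stays within the scatter. Compound 4 is estimated at 90 nM, with a range from 35 nM to 250 nM.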

Compound 4, half-maximal inhibitory concentration: 120 nM
The estimate for compound 4 lay 1.3-fold (0.12 log units) below the measured number, within the range that was stated.
By their numbers in this assay, from the lowest: compounds 3, 2 and 4 (each within the scatter of the next); then compound 1.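

In this assay, the 2-ethyl-4-methyl-1-propyl-1H-imidazol-5-yl group, which carries a 1-propyl chain that neither earlier imidazole nor thiazole group has, is tolerated on the saturated chain carbon bound to an amine nitrogen in a ring: no change at the digits printed from compound 2 to compound 4 (within the scatter), and a 1.5-fold higher number from compound 3 to compound 4 (0.19 log units; within the scatter). The separation from the oxazole group also holds for this larger group, with a 6.2-fold lower number from compound 1 to compound 4 (0.79 log units; beyond the scatter), so among the four compounds shown the thiazole group and both imidazole groups form one level and only compound 1 stands apart. No measurement is available to explain this tolerance or the separation of compound 1.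

Within the data shown here, compound 3 and compound 4 differ in the 1-substituent, the attachment through the 4-yl or 5-yl position and the 4-methyl group all at once, so no single pair assigns a contribution to any one of these features. Also open, going by these compounds, is how far this tolerance extends, for instance whether a 1-butyl chain, a 1-benzyl group, or a carboxylic acid or an amine at the end of the 1-propyl chain would stay at the same level.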